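The compounds below may be only part of what the source reports. "The series", "measured", "known", "first", "only" and "open" are said of these compounds alone.

Measured compounds:
- compound 1 `CCc1cccc(NC(=O)c2cccc(/C=C3\CC(=O)N(c4ccccc4)C3=O)c2)c1`: 81200 nM
- compound 2 `O=C(Nc1ccc(Cl)cc1)c1cccc(/C=C2\CC(=O)N(c3ccccc3)C2=O)c1`: > 100000 nM
- compound 3 `CSc1cccc(NC(=O)c2cccc(/C=C3\CC(=O)N(c4ccccc4)C3=O)c2)c1`: 65200 nM

In an ADME assay on HCT-116 cells (Homo sapiens) for cytotoxicity, read by MTT assay, with a stated time of 72 h (a lower number here means a stronger inhibitor, a higher number a weaker inhibitor), compound 1 gives 81200 nM. Compound 2 reaches only a limit of this assay, > 100000 nM (the limit of > 100000 nM in this assay, at which 1 of the 3 values shown sits). Compound 3 gives 65200 nM, the lowest of the two numbers, yet the step of a 1.2-fold lower number from compound 1 to compound 3 (0.10 log units; within the scatter) sits within scatter, and so does an at least 1.5-fold lower number from compound 2 to compound 3 (0.18 log units; that floor lies within the scatter). The whole series is therefore flat.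

Compound 4 `O=C(Nc1ccc(OC(F)F)cc1)c1cccc(/C=C2\CC(=O)N(c3ccccc3)C2=O)c1` differs from compound 3 by 4-(difluoromethoxy)phenyl in place of 3-(methylsulfanyl)phenyl on an amide-type nitrogen. Among the compounds with values here, the steps that bear on this are the two earlier exchanges of the aryl on the amide-type nitrogen, an at least 1.2-fold higher number from compound 1 to compound 2 (0.09 log units; that floor lies within the scatter) and an at least 1.5-fold lower number from compound 2 to compound 3 (0.18 log units; that floor lies within the scatter), both within scatter, with compound 2 sitting at the limit. No step beyond the scatter is expected in this assay, and a move toward the limit cannot be excluded. Compound 4 is estimated at 90000 nM, between 45000 nM and 180000 nM, which means an expected step of a 1.4-fold higher number from compound 3 to compound 4 (0.14 log units; within the scatter).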

Compound 4, half-maximal inhibitory concentration: > 100000 nM
Compound 4: no number, only a limit; the forecaster's own chance of this, stated with the estimate: 40%; at least 1.1-fold (0.04 log units) between middle value and limit.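

In this assay compound 4 gives > 100000 nM, which is a limit of the assay and not a number. The exchange on the amide-type nitrogen gives an at least 1.5-fold higher number from compound 3 to compound 4 (0.18 log units; that floor lies within the scatter) and an at least 1.2-fold higher number from compound 1 to compound 4 (0.09 log units; that floor lies within the scatter), so 4-(difluoromethoxy)phenyl shows no readable separation from 3-(methylsulfanyl)phenyl or 3-ethylphenyl, and the step between the two limit compounds cannot be read. A second 4-substituted phenyl now sits at the limit, as in compound 2, while the 3-substituted compounds 1 and 3 give numbers, though no step printed here supports a real effect of substituent position: the limit of > 100000 nM in this assay, at which 2 of the 4 values shown sit.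

On these data alone, whether any aryl on this nitrogen can give a step beyond the scatter stays open. As far as these compounds go, the effect of an amine or a carboxylic acid on this ring also remains unknown.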